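The source may hold more compounds than are shown below. What is called first, only, known or untested is meant among the compounds shown, and "the series" means these compounds.

Measured so far:
- compound 1, `CCCCc1ccc(C)c(=O)n1Cc1ccc(-c2ccccc2-c2nn[nH]n2)cc1`, with 7 nM
- compound 2, `CCCCNC(=O)NCc1ccc(CCCC)n(Cc2ccc(-c3ccccc3-c3nn[nH]n3)cc2)c1=O`, with 10 nM
- compound 3, `CCCCc1ccc(CNS(=O)(=O)c2ccc(C)cc2)c(=O)n1Cc1ccc(-c2ccccc2-c2nn[nH]n2)cc1`, with 9 nM

All three numbers come from a functional assay (aorta) for antagonist activity, with Oryctolagus cuniculus as the target; on this read-out higher numbers stand for weaker inhibition and lower numbers for stronger inhibition. For the measured compounds named here, compound 2, which carries a butylcarbamoyl group on the amine nitrogen, sits together with the other two inside the usual scatter of this assay: the steps that connect it are a 1.4-fold higher number from compound 1 to compound 2 (0.15 log units; within the scatter) and a 1.1-fold lower number from compound 2 to compound 3 (0.05 log units; within the scatter), so no compound among the three can be set apart from the others.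

Compound 4, `CCCCc1ccc(CNS(C)(=O)=O)c(=O)n1Cc1ccc(-c2ccccc2-c2nn[nH]n2)cc1`, has not yet been measured in this assay. Its change from compound 2 is methylsulfonyl in place of butylcarbamoyl on an amine nitrogen. The step that bears most directly on it is a 1.1-fold lower number from compound 2 to compound 3 (0.05 log units; within the scatter), where one group on that same amine nitrogen was exchanged for another and the number barely moved. The steps of a 1.4-fold higher number from compound 1 to compound 2 (0.15 log units; within the scatter) and a 1.3-fold higher number from compound 1 to compound 3 (0.11 log units; within the scatter) tell the same story: putting either group onto the saturated chain carbon bound to an aromatic carbon changed little. Nothing in these three compounds points to a move beyond the scatter in either direction for a further exchange at this position.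

Compound 4 is therefore expected to give about 10 nM, within a range from 5 nM to 22 nM. The step expected is no change at the digits printed from compound 2 to compound 4 (within the scatter), that is, none beyond the scatter.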

Compound 4, half-maximal inhibitory concentration: 2 nM
The estimate for compound 4 lay 5.0-fold (0.70 log units) above the measured number, outside the stated range (below it).
By their numbers in this assay, from the lowest: compound 4; then compounds 1, 3 and 2 (each within the scatter of the next).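

On the amine nitrogen, the group attached can matter in this assay, even though butylcarbamoyl and (4-methylphenyl)sulfonyl could not be told apart: methylsulfonyl in place of butylcarbamoyl gives a 5.0-fold lower number from compound 2 to compound 4 (0.70 log units; beyond the scatter) in this read-out, a shift towards stronger inhibition. The sulfonyl group alone does not account for the shift, as compound 3 carries one too, and exchanging only the 4-methylphenyl on the sulfonyl sulfur for methyl gives a 4.5-fold lower number from compound 3 to compound 4 (0.65 log units; beyond the scatter) and so singles out the group on the sulfur. Compared with hydrogen on the saturated chain carbon, methanesulfonamido gives a 3.5-fold lower number from compound 1 to compound 4 (0.54 log units; beyond the scatter) and is the only one of the three additions there to move the number beyond the scatter, but nothing available here explains why this exchange lowers the number.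

Still open, on these data alone, is whether a longer chain on the sulfonyl sulfur, such as ethyl or butyl, would hold the number near that of compound 4 or return it towards that of compound 3. Also open, as far as these compounds go, is whether methylcarbamoyl on the amine nitrogen would match methylsulfonyl, which would show whether the sulfonyl group is needed for the shift at all.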